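The source may report more compounds than this note shows. Statements on the series, on what has been measured and on what is new or still open speak of the compounds shown alone.

Measured in an ADME assay on the whole organism (Mus musculus, strain ICR) for pharmacokinetics, read by HPLC, with a stated time of 24 h, at a dose of 50 mg/kg by the oral route; on this read-out lower numbers stand for lower exposure and higher numbers for higher exposure at the dose given:
- compound 1 `CCc1nc2ccc(Br)cn2c1C(=O)NCCOc1ccc(N2CCC(C(F)(F)F)CC2)cc1` gives 7120 ng.h/mL
- compound 2 `CCc1nc2ccc(Cl)cn2c1C(=O)NCCOc1ccc(N2CCN(c3ccc(F)cc3)CC2)cc1` gives 11100 ng.h/mL
- compound 3 `COc1ccc2nc(C)c(C(=O)NCCOc3ccc(N4CCC(C(F)(F)F)CC4)cc3)n2c1` gives 754 ng.h/mL

Compound 1 lies within the scatter of compound 2, while compound 3 gives a lower number, beyond the scatter. Compound 1 therefore sits with compound 2 in the upper part of this small set.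

Compound 4 `CCc1nc2ccc(Br)cn2c1C(=O)NCCOc1ccc(N2CCCCC2)cc1` has not yet been measured. It differs from compound 1 by hydrogen in place of trifluoromethyl on a saturated ring carbon, so that 4-(trifluoromethyl)piperidin-1-yl becomes piperidin-1-yl.

Among the compounds with values here, no measured pair isolates this change. Trifluoromethyl is present in compound 3 at 754 ng.h/mL and absent from compound 2 at 11100 ng.h/mL, so the three numbers give no clear direction for it. A moderate move towards lower exposure is nevertheless expected, with the estimated step of a 2.4-fold lower number from compound 1 to compound 4 (0.38 log units; beyond the scatter), and the range is kept wide on this thin evidence. The expected value for compound 4 is 3000 ng.h/mL, with an estimated range of 900 ng.h/mL to 9000 ng.h/mL.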

Compound 4, area under the concentration-time curve: 818 ng.h/mL
The estimate for compound 4 lay 3.7-fold (0.56 log units) above the measured number; the whole stated range lies above it.
By their numbers in this assay, from the lowest: compounds 3 and 4 (each within the scatter of the next); then compounds 1 and 2 (each within the scatter of the next).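

Hydrogen in place of trifluoromethyl on this saturated ring carbon gives the first single-change reading at this position: in this assay the step is large (an 8.7-fold lower number from compound 1 to compound 4 (0.94 log units; beyond the scatter)). With the rest of compound 1 held constant, the exposure reading therefore depends strongly on what this ring carbon carries, so 4-(trifluoromethyl)piperidin-1-yl cannot be treated as interchangeable with piperidin-1-yl in this series. This rests on one pair, and nothing available gives a cause for the step.

Going by these compounds, whether the higher reading is specific to trifluoromethyl remains open, and a methyl, a single fluorine or a hydroxyl on the same ring carbon would test this. Also open, on these data alone, is whether the same change would give a step of similar size on the core of compound 3.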